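The compounds below may be only part of what the source reports. "The series", "measured", "known", "first", "only" and "open" are said of these compounds alone.

Measured so far:
compound 1 `CC(C)c1ccc(-n2cc(-c3cn([C@H]4C[C@H](O)[C@@H](CO)O4)c(=O)[nH]c3=O)nn2)cc1` — 29000 nM
compound 2 `O=c1[nH]c(=O)n([C@H]2C[C@H](O)[C@@H](CO)O2)cc1-c1cnnn1-c1c(F)cccc1F` — 10000 nM

In an ADME assay on L1210 cells (Mus musculus) for cytotoxicity, read by cell counting, with a stated time of 2 days (a higher number here means a weaker inhibitor, a lower number a stronger inhibitor), compound 2 gives 10000 nM, the lower of the two numbers. Compound 1 gives 29000 nM, a gap beyond the scatter. Compound 3 `O=c1[nH]c(=O)n([C@H]2C[C@H](O)[C@@H](CO)O2)cc1-c1cnnn1-c1ccc(Br)cc1` differs from compound 2 by 4-bromophenyl in place of 2,6-difluorophenyl on an aromatic nitrogen. Among the compounds with values here, no measured pair shows this change, so the size of the step is open; the only anchor is that compound 1, the other aryl variant, sits higher. The expected step is a 2.0-fold higher number from compound 2 to compound 3 (0.30 log units; within the scatter), toward a higher number, of a size near the edge of the scatter. Compound 3 is estimated at 20000 nM, within 7000 nM to 60000 nM.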

Compound 3, half-maximal inhibitory concentration: 61000 nM
Compound 3: the middle estimate sits 3.1-fold (0.48 log units) below what was measured; measured number outside the range, above it.
By their numbers in this assay, from the lowest: compound 2; then compound 1; then compound 3.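

The aryl group on the aromatic nitrogen is not a neutral position in this assay: 4-bromophenyl in place of 2,6-difluorophenyl gives a 6.1-fold higher number from compound 2 to compound 3 (0.79 log units; beyond the scatter). Within the data shown here, this is the first change in a single place that the series can read, and it moves toward weaker inhibition. No measurement at hand bears on the reason for this step.

A single pair cannot separate the loss of the two fluorines from the gain of the bromine. As far as these compounds go, how an unsubstituted phenyl or an aminophenyl at this nitrogen would compare with compound 2 remains open.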